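The source may hold more compounds than are shown below. What is called first, only, known or untested is meant among the compounds shown, and "the series" means these compounds.

Measured so far:
compound 1 `Nc1scc(-c2ccccc2)c1C(=O)c1ccc(Cl)cc1` — 51%
compound 2 `Nc1scc(-c2ccc(F)cc2)c1C(=O)c1ccc(Cl)cc1` — 62%
compound 3 `Nc1scc(-c2ccc(Cl)cc2)c1C(=O)c1ccc(Cl)cc1` — 50%

In a functional assay on CHO cells for agonist activity at adenosine receptor A1 (Homo sapiens), read by fluorescence and ERK phosphorylation, with stated times of 30 min and 1.5 h, tested at 3 uM (a lower number here means a weaker effect, a higher number a stronger effect of the compound at the concentration tested), compound 3 gives 50%, the lowest of the three numbers. Against compound 1 the step is a number 1 percentage points lower from compound 1 to compound 3 (within the scatter); against compound 2 it is a number 12 percentage points lower from compound 2 to compound 3 (beyond the scatter). Compound 4 `Nc1scc(-c2ccc([N+](=O)[O-])cc2)c1C(=O)c1ccc(Cl)cc1` is not yet measured. It differs from compound 3 by nitro in place of chloro on an aromatic carbon. Among the measured compounds shown here, the steps that bear on this position are a number 11 percentage points higher from compound 1 to compound 2 (beyond the scatter), a number 1 percentage points lower from compound 1 to compound 3 (within the scatter) and a number 12 percentage points lower from compound 2 to compound 3 (beyond the scatter): all modest or within the scatter, and none involves a nitro group, so the direction for compound 4 is not fixed by the data. A step near the edge of the scatter, either way, is expected. Compound 4 is estimated at 55%, between 40% and 70%. The expected step is a number 5 percentage points higher from compound 3 to compound 4 (within the scatter).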

Compound 4, a percentage reported as activity, at one concentration (the size of the read-out at that concentration, not a potency): 47%
Compound 4: middle estimate off by 8 percentage points, on the high side; measured number inside the range.
By their numbers in this assay, from the lowest: compounds 4, 3 and 1 (each within the scatter of the next); then compound 2.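

In this assay, nitro on this aromatic carbon, para to a large group, brings three heavy atoms and two hydrogen-bond acceptors, yet the read-out stays level with chloro (a number 3 percentage points lower from compound 3 to compound 4 (within the scatter)) and with hydrogen (a number 4 percentage points lower from compound 1 to compound 4 (within the scatter)). Only fluoro stands apart (a number 15 percentage points lower from compound 2 to compound 4 (beyond the scatter)), so across these four compounds compound 2 is the single one separated from the rest. No measured data bear on why the read-out follows this pattern.

From the compounds shown here alone, whether an amine or a carboxylic acid here would also stay level with hydrogen remains open. So does whether a methoxy group would separate from that level as fluoro does.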